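The source may hold more compounds than are shown below. What is called first, only, known or untested is meant among the compounds shown, and "the series" means these compounds.

Compound 1 `CCS(=O)(=O)Nc1ccc2c(c1)S(=O)(=O)N=C(c1c(O)c(-c3cccs3)nn(CCC(C)C)c1=O)N2` was examined in an ADME assay on Huh-7 cells (Homo sapiens) for cytotoxicity, with a stated time of 72 h; on this read-out lower numbers stand for higher toxicity in this test and higher numbers for lower toxicity in this test. In this assay compound 1 gives > 33000 nM, which is a limit rather than a number. Compound 2 `CCCS(=O)(=O)Nc1ccc2c(c1)S(=O)(=O)N=C(c1c(O)c(-c3cccs3)nn(CCC(C)C)c1=O)N2` carries methyl in place of hydrogen on a saturated chain carbon, two bonds along the chain from a sulfonyl sulfur. In this assay compound 2 gives > 1000 nM, likewise a limit. The step that the two limits leave unreadable from compound 1 to compound 2 is therefore not readable. Compound 3 `CC(C)Cn1nc(-c2cccs2)c(O)c(C2=NS(=O)(=O)c3cc(NS(C)(=O)=O)ccc3N2)c1=O` has a different core; that difference between the two cores is not broken down here. In this assay compound 3 gives > 1000 nM, again a limit. Compound 4 `CC(C)(C)Cn1nc(-c2cccs2)c(O)c(C2=NS(=O)(=O)c3cc(NS(C)(=O)=O)ccc3N2)c1=O` carries methyl in place of hydrogen on a saturated chain carbon bound to three saturated chain carbons, the same kind of change as that from compound 1 to compound 2, though here on a saturated chain carbon bound to three saturated chain carbons rather than two bonds along the chain from a sulfonyl sulfur. Because the limit of > 1000 nM in this assay, at which 2 of the 3 values shown sit, and the limit of > 33000 nM in this assay, at which 1 of the 3 values shown sits, account for all three values, the step expected here, a step that the limit leaves unreadable from compound 3 to compound 4, is small next to the unreadable a step that the two limits leave unreadable from compound 1 to compound 2. Compound 4 is estimated at 30000 nM, expected between 5000 nM and 100000 nM.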

Compound 4, half-maximal cytotoxic concentration: > 1000 nM
Compound 4 gave a limit, no number; the forecaster's own chance of this, stated with the estimate: 80%; the middle value lies beyond the limit too.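

Compound 3 and compound 4 both give only a limit in this assay, so no step can be read between them. The compounds shown leave open whether methyl in place of hydrogen at this place changes the half-maximal cytotoxic concentration at all.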